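This account rests on a few compounds, and the source may have more. Where it says the series, first, only, none or still open, it means among the compounds named here.

Measured in a functional assay on HepG2 cells (Homo sapiens), read by MTT assay, with a stated time of 48 h; on this read-out lower numbers stand for stronger inhibition and higher numbers for weaker inhibition:

- compound 1 `CCN(CC)CCCNC(=O)c1ccc(C(CC)(CC)c2ccc(OCC(=O)C(C)(C)C)c(C)c2)n1CC`: 180 nM
- compound 2 `CCn1c(C(=O)NCCN)ccc1C(CC)(CC)c1ccc(OCC(=O)C(C)(C)C)c(C)c1`: 180 nM
- compound 3 `CCOC(=O)CN(C)C(=O)c1ccc(C(CC)(CC)c2ccc(OCC(O)C(C)(C)C)c(C)c2)n1CC`: > 50000 nM, a limit of the assay and not a number

Compound 3 stands at the limit of > 50000 nM in this assay, at which 1 of the 3 values shown sits. Compound 4 `CCn1c(C(=O)NCCCN(C)C)ccc1C(CC)(CC)c1ccc(OCC(O)C(C)(C)C)c(C)c1` differs from it in one place: (3-(dimethylamino)propyl)amino in place of ((ethoxycarbonyl)methyl)(methyl)amino on a carbonyl carbon. In words, (3-(dimethylamino)propyl)amino enters in place of ((ethoxycarbonyl)methyl)(methyl)amino on a carbonyl carbon.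

Among the measured compounds shown here, only one measured step touches such an amine-ended chain: no change at the digits printed from compound 1 to compound 2 (within the scatter). That step is small, and it does not cover the exchange made here. For the measured compounds named here, no measured step links compound 4 to compound 1 or compound 2, so any expectation remains loose. Even so, both amine-bearing compounds give numbers well inside the range of this assay, with compound 1 at 180 nM and compound 2 at 180 nM. On that basis, a large move towards stronger inhibition is expected: an at least 50-fold lower number from compound 3 to compound 4 (1.69 log units; beyond the scatter). For compound 4 the estimated value is 1000 nM, with an expected range from 150 nM to 15000 nM.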

Compound 4, half-maximal inhibitory concentration: 360 nM
Compound 4: the middle estimate sits 2.8-fold (0.44 log units) above what was measured; the range from low to high includes it.
By their numbers in this assay, from the lowest: compounds 1, 2 and 4 (each within the scatter of the next). At a limit, above all of these: compound 3.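

In this assay the exchange on the carbonyl carbon gives an at least 130-fold lower number from compound 3 to compound 4 (2.14 log units; beyond the scatter) and shows that, with the rest of the molecule the same, the group at this place has a large effect on the read-out. Among the compounds shown here, the only earlier step reads no change at the digits printed from compound 1 to compound 2 (within the scatter) and swaps one amine-ended chain for another, so it could not show how much depends on the group on this carbonyl carbon. The size of the new step is only a lower bound, for compound 3 stands at a limit: the limit of > 50000 nM in this assay, at which 1 of the 4 values shown sits.

Still open, on these data alone, is whether the dimethylamino end accounts for the step, which a plain propylamino group at the same place would test. Equally open, as far as these compounds go, is how far the ethoxycarbonyl ester matters, which a carboxylic acid in its place would help to separate.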